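The compounds below may be only part of what the source reports. "The series", "measured", "known", "first", "only" and "open" are said of these compounds alone.

The measured compounds:

compound 1 `COc1cc2c(cc1CC=C(C)C)/C(=N/NC(N)=O)C[C@@H](c1ccc(O)cc1)O2`: 87%
compound 2 `COc1cc2c(cc1CC=C(C)C)C(=O)C[C@@H](c1ccc(Oc3ccccc3)cc1)O2`: 76%
compound 3 `C#CCO/N=C1/C[C@@H](c2ccc(OC)cc2)Oc2cc(OC)c(CC=C(C)C)cc21`: 65%

All three share one core and were tested in a functional assay on HCT-116 cells (Homo sapiens) for inhibition, read by sulforhodamine B assay, with a stated time of 48 h, tested at 50 uM; a higher number here means more inhibition of growth at the concentration tested, a lower number less inhibition of growth. Compound 1 gives 87%, compound 2 gives 76%, and compound 3 gives 65%. Compound 2 therefore stands second highest of the three numbers; compound 1 lies nearest to it with a higher number, beyond the scatter, and compound 3 lies furthest with a lower number, also beyond the scatter.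

The next compound, compound 4 `COc1cc2c(cc1CC=C(C)C)C(=O)C[C@@H](c1ccc(Oc3cccc([N+](=O)[O-])c3)cc1)O2`, differs from compound 2 in one place: nitro in place of hydrogen on an aromatic carbon. Within the data shown here, no step between two measured compounds shows what this change does, so the expectation rests on compound 2 alone. Since the change is a single group on the outer ring of the phenoxy substituent, the step is expected to be small, most likely within the scatter, with a slight lean downward rather than upward. The expected step from compound 2 to compound 4 in this assay is a number 4 percentage points lower from compound 2 to compound 4 (within the scatter). Compound 4 is thus estimated to give 72%, in a range from 55% to 86%.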

Compound 4, percent growth inhibition at one concentration: 46%
The estimate for compound 4 lay 26 percentage points above the measured number; the measured number lies below the stated range.
By their numbers in this assay, from the lowest: compound 4; then compound 3; then compound 2; then compound 1.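

In this assay, among these compounds, nitro in place of hydrogen on an aromatic carbon, which turns phenoxy into 3-nitrophenoxy, gives a number 30 percentage points lower from compound 2 to compound 4 (beyond the scatter), the first single change that can be read in this set. It shows that the outer ring of the phenoxy substituent is not indifferent to what it carries: one added group on that ring, far out from the shared core, moves the number by more than the scatter, so growth inhibition at the concentration tested responds to changes made at this end of the molecule. Nothing measured alongside these numbers accounts for the drop, so the step stands as an observation only.

An amine or a carboxylic acid on the same ring carbon would show whether the drop belongs to nitro itself or to almost any group placed there. As far as these compounds go, it also stays open whether nitro on another carbon of that ring would give a similar step, and whether the same change would act alike on the cores of compound 1 or compound 3, which carry a different substituent on that side.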